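The compounds below may be only part of what the source reports. "The series", "measured", "known", "first", "only" and "open" are said of these compounds alone.

Measured in a physicochemical assay for solubility, read by spectrophotometry, at pH 6.8; a higher number here means a more soluble compound, a lower number a less soluble compound:

- Compound 1 `CCOC(=O)CCNc1cc(Nc2ccc3[nH]c(=O)[nH]c3c2)c(Cl)cc1[N+](=O)[O-]`: 0.42 ug/mL
- Compound 2 `O=C(O)CCNc1cc(Nc2ccc3[nH]c(=O)[nH]c3c2)c(Cl)cc1[N+](=O)[O-]`: > 72 ug/mL (a limit, not a number)

Compound 2 stands at the limit of > 72 ug/mL in this assay, at which 1 of the 2 values shown sits, so no exact number is known for it. Compound 3 `O=c1[nH]c2ccc(Nc3cc(NCc4cccnc4)c([N+](=O)[O-])cc3Cl)cc2[nH]1` differs from compound 2 by pyridin-3-yl in place of carboxymethyl on a saturated chain carbon bound to a nitrogen on an aromatic ring. In words, pyridin-3-yl takes the place of carboxymethyl. Among the compounds with values here, the one measured step that bears on this change is large: an at least 170-fold higher number from compound 1 to compound 2 (2.23 log units; beyond the scatter). It was made on the same chain, with hydrogen in place of ethyl. Compound 3 keeps neither that hydrogen nor the carboxymethyl, so a large step down is expected in this assay, towards compound 1 at 0.42 ug/mL. Pyridin-3-yl has no measured counterpart here, so the range is kept wide. The expected step is an at least 60-fold lower number from compound 2 to compound 3 (1.77 log units; beyond the scatter). Compound 3 is estimated at 1.2 ug/mL, with an expected range from 0.25 ug/mL to 7 ug/mL.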

Compound 3, solubility: < 0.23 ug/mL
Compound 3 was reported as a limit; the forecaster's own chance of this, stated with the estimate: 5%; at least 5.2-fold (0.71 log units) between middle value and limit.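

Placing pyridin-3-yl where carboxymethyl stood, on a saturated chain carbon bound to a nitrogen on an aromatic ring, gives in this assay an at least 310-fold lower number from compound 2 to compound 3 (2.49 log units; beyond the scatter), so the high reading of compound 2 does not carry over to this ring at the same place. Set against the ester, the same ring gives an at least 1.8-fold lower number from compound 1 to compound 3 (0.26 log units; that floor lies within the scatter), so compound 1 and compound 3 cannot be put in order, and of the three only compound 2, with its free carboxylic acid, stands at the high end. Compound 3 therefore marks the low end only as a limit, not as a number: the limit of < 0.23 ug/mL in this assay, at which 1 of the 3 values shown sits.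

From the compounds shown here alone, it remains open whether an amine at the end of this chain would read nearer to compound 2 or to compound 3. Going by these compounds, a longer chain ending in a carboxylic acid also remains untested against compound 2.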